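This account rests on a few compounds, and the source may have more. Where it says the series, first, only, none or still open, it means among the compounds named here.

In a functional assay on HeLa cells (Homo sapiens) for cytotoxicity, read by MTT assay, with a stated time of 72 h (on this read-out higher numbers stand for weaker inhibition and lower numbers for stronger inhibition), compound 2 `NC(=O)c1cn(Cc2nnc(-c3cc(S(N)(=O)=O)c(SCc4ccccc4)cc3Cl)o2)nn1` gives 75000 nM, the lowest of the two numbers in the series, and compound 1 `NS(=O)(=O)c1cc(-c2nnc(CN3CCN(c4ccccc4)CC3)o2)c(Cl)cc1SCc1ccccc1` gives 100000 nM. For the measured compounds named here, the only measured step is a 1.3-fold lower number from compound 1 to compound 2 (0.12 log units; within the scatter); it alters the group on the saturated chain carbon, not the ring carbon changed here, so no measured step bears directly on the next move. Compound 3 `NS(=O)(=O)c1cc(-c2nnc(/C=C/c3ccccc3)o2)c(Cl)cc1SCc1ccccc1` differs from compound 2 by 2-phenylethenyl in place of (4-carbamoyl-1H-1,2,3-triazol-1-yl)methyl on an aromatic carbon. Going by the values given here, with both measured numbers close together and no guiding step, compound 3 is expected to remain near compound 2, with no step beyond the scatter. The estimated step is a 1.3-fold lower number from compound 2 to compound 3 (0.10 log units; within the scatter). Compound 3 is estimated at 60000 nM, range 15000 nM to 100000 nM.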

Compound 3, half-maximal inhibitory concentration: 14000 nM
The estimate for compound 3 lay 4.3-fold (0.63 log units) above the measured number; the measured number lies below the stated range.
By their numbers in this assay, from the lowest: compound 3; then compounds 2 and 1 (each within the scatter of the next).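

In this assay, for the compounds shown here, this position, on the five-membered aromatic ring with 2 nitrogen and 1 oxygen, gives the first step beyond the scatter: a 5.4-fold lower number from compound 2 to compound 3 (0.73 log units; beyond the scatter) with 2-phenylethenyl in place of (4-carbamoyl-1H-1,2,3-triazol-1-yl)methyl. The entering group is all carbon, with 0 hydrogen-bond donors and 0 hydrogen-bond acceptors, so the step swaps the whole group rather than one feature of it. No measurement available here explains this step.

Still open, as far as these compounds go, is which part of 2-phenylethenyl goes with the lower number. A saturated 2-phenylethyl chain or a phenyl directly on the ring at this position would help separate the double bond from the phenyl ring.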